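The compounds below may be only part of what the source reports. "The series", "measured", "known", "first", "only" and "open" are said of these compounds alone.

Working notes on the series.

Three analogues share one core and differ only in the aryl group on the carbon with a double bond to nitrogen. Compound 1 `CN(C)CCn1cnnc1-c1cc(Oc2ccc(NC(=O)N/N=C/c3ccc(F)cc3F)cc2F)ccn1` gives 1930 nM in a functional assay on NCI-H460 cells (Homo sapiens) for cytotoxicity, read by MTT assay, with a stated time of 72 h; a higher number here means a weaker inhibitor, a lower number a stronger inhibitor. Compound 2 `CN(C)CCn1cnnc1-c1cc(Oc2ccc(NC(=O)N/N=C/c3cccc(Cl)c3Cl)cc2F)ccn1` gives 72 nM in this assay, and compound 3 `CN(C)CCn1cnnc1-c1cc(Oc2ccc(NC(=O)N/N=C/c3ccc(Cl)cc3)cc2F)ccn1` gives 320 nM in this assay. Compound 3 stands second highest of the three: the step of a 4.4-fold higher number from compound 2 to compound 3 (0.65 log units; beyond the scatter) and the step of a 6.0-fold lower number from compound 1 to compound 3 (0.78 log units; beyond the scatter) both lie beyond the scatter, as does the step of a 27-fold lower number from compound 1 to compound 2 (1.43 log units; beyond the scatter).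

Compound 4 `COc1ccc(/C=N/NC(=O)Nc2ccc(Oc3ccnc(-c4nncn4CCN(C)C)c3)c(F)c2)cc1O` is not yet measured. The change is 3-hydroxy-4-methoxyphenyl in place of 4-chlorophenyl on a carbon with a double bond to nitrogen. All three measured steps concern this same aryl group, and each of them moved the number by a modest to large amount, so the group clearly matters; none of them, however, involves a hydroxy or methoxy substituent, so the direction is not settled by the data. A step of at least modest size in this assay is expected for compound 4, with a weakening more likely than a gain given the absence of any precedent for the entering group. The step of a 2.0-fold higher number from compound 3 to compound 4 (0.31 log units; beyond the scatter) is the estimate. Compound 4 is expected to give about 650 nM in this assay, within 150 nM to 3000 nM.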

Compound 4, half-maximal inhibitory concentration: 620 nM
Estimate against measurement, compound 4: 1.0-fold (0.02 log units) above, within the range that was stated.
By their numbers in this assay, from the lowest: compound 2; then compounds 3 and 4 (each within the scatter of the next); then compound 1.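

In this assay, a 3-hydroxy-4-methoxyphenyl group on the carbon with a double bond to nitrogen cannot be told apart from 4-chlorophenyl, with a 1.9-fold higher number from compound 3 to compound 4 (0.29 log units; within the scatter), so a halogen on this aryl group is not required for a number in this range. The same group remains clearly separated from both halogenated neighbours, with an 8.6-fold higher number from compound 2 to compound 4 (0.94 log units; beyond the scatter) and a 3.1-fold lower number from compound 1 to compound 4 (0.49 log units; beyond the scatter), which places compound 4 inside the span set by compound 1 and compound 2. No outside measurement bears on these differences.

On these data alone, the hydroxy and methoxy groups occur only together here, so their separate contributions remain open. Also open, as far as these compounds go, is how an aryl group carrying an amine or a carboxylic acid would read in this assay.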